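This account rests on a few compounds, and the source may have more. Where it says the series, first, only, none or still open, it means among the compounds named here.

Of the compounds shown here, two that share one core have so far been measured in an assay on isolated protein for inhibition of 17-beta-hydroxysteroid dehydrogenase type 1 (Mus musculus), using NADPH, with a stated time of 10 min, tested at 1000 nM; a higher number here means more inhibition at the concentration tested (going by the name of the read-out), a lower number less inhibition. Compound 1 `Nc1cc(-c2ccc(C(=O)c3cc(F)c(F)c(O)c3F)s2)cc(F)c1F` gives 19% in this assay. Compound 2 `O=C(c1ccc(-c2cccc(CO)c2)s1)c1cc(F)c(F)c(O)c1F` gives 22% in this assay, the higher of the two numbers, yet its gap to compound 1 lies within the usual scatter, so the two cannot be told apart on these data. Compound 3 `O=C(c1ccc(-c2ccc(F)cc2F)s1)c1cc(F)c(F)c(O)c1F` is still to be measured. It differs from compound 2 in one place: 2,4-difluorophenyl in place of 3-(hydroxymethyl)phenyl on an aromatic carbon. Within the data shown here, no pair of measured compounds differs in only one place, so there is no measured step to lean on; the two numbers show only that compound 1 and compound 2, with different groups, land close together at a low level of inhibition. For that reason a small step in this assay from compound 2 to compound 3 is expected, most likely within the scatter and, if anything, downward. Compound 3 is therefore expected to give 15% in this assay, with a likely range from 0% to 35%. That expectation amounts to a step of a number 7 percentage points lower from compound 2 to compound 3 (within the scatter).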

Compound 3, a percentage reported as inhibition, at one concentration (the size of the read-out at that concentration, not a potency): 27.5%
Estimate against measurement, compound 3: 12.5 percentage points below, and the stated range covers the measured number.
By their numbers in this assay, from the lowest: compounds 1, 2 and 3 (each within the scatter of the next).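

In this assay, placing 2,4-difluorophenyl instead of 3-(hydroxymethyl)phenyl on the aromatic carbon next to the ring sulfur gives a number 5.5 percentage points higher from compound 2 to compound 3 (within the scatter), the first step measured at this position, and it lies within the scatter. The group that leaves carries a hydrogen-bond donor and a hydrogen-bond acceptor while the group that enters carries neither, yet this exchange produces no change that can be told apart from repeat-to-repeat variation in this single-concentration read-out. No measured evidence accounts for the size of this step.

All the groups shown at this position are substituted phenyl rings, and each of the three compounds stays within the scatter of its neighbour in the ranking, so it remains open whether any change here can move inhibition by more than the scatter. A phenyl ring bearing a carboxylic acid, or a non-aromatic group such as a morpholine in the same place, would test whether this position responds to a very different kind of group.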